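Cytotoxicity notes on three measured compounds and one pending

The source may report more compounds than this note shows. Statements on the series, on what has been measured and on what is new or still open speak of the compounds shown alone.

Measured so far:
compound 1 `COc1cccc(S(=O)(=O)/C=C/c2ccccn2)c1` gives 98.9%
compound 2 `COc1ccc(S(=O)(=O)/C=C/c2ccccn2)cc1` gives 100%
compound 3 `COc1cccc(S(=O)(=O)/C=C/c2cccnc2)c1` gives 90.8%

The read-out is an ADME assay on BV-2 cells (Mus musculus) for cytotoxicity, with a stated time of 24 h, tested at 50 uM; on this read-out higher numbers stand for a weaker effect at the one concentration tested and lower numbers for a stronger effect. All three values of this assay lie within the usual scatter of one another, so no ordering among compound 1, compound 2 and compound 3 is supported by these numbers.

Going by the values given here, the one single-point change that has been measured is pyridin-3-yl in place of pyridin-2-yl on a double-bonded chain carbon bound to a double-bonded chain carbon. It produced a number 8.1 percentage points lower from compound 1 to compound 3 (within the scatter), a step that stays inside the scatter.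

Compound 4 `COc1ccc(S(=O)(=O)/C=C/c2cccnc2)cc1` has not yet been measured in this assay. Among the compounds with values here, it relates to compound 2 by pyridin-3-yl in place of pyridin-2-yl on a double-bonded chain carbon bound to a double-bonded chain carbon, which is the same change as the one from compound 1 to compound 3, at the same place on the chain. The cores of compound 1 and compound 2 differ, but that difference is not broken down here; the two values of those compounds show nothing beyond the scatter.

For compound 4 the step of a number 7 percentage points lower from compound 2 to compound 4 (within the scatter) is expected, resting on the earlier step because a number 8.1 percentage points lower from compound 1 to compound 3 (within the scatter) was the only measured effect of this change. Compound 4 is accordingly estimated at 93%, with 82% and 100% as the expected range in this assay.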

Compound 4, a percentage reported as activity, at one concentration (the size of the read-out at that concentration, not a potency): 85.8%
Estimate against measurement, compound 4: 7.2 percentage points above; measured number inside the range.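

In this assay, going by these compounds alone, pyridin-3-yl in place of pyridin-2-yl on a double-bonded chain carbon bound to a double-bonded chain carbon gives a number 14.2 percentage points lower from compound 2 to compound 4 (beyond the scatter) and this modest step is the only reading of the change that clears the scatter. The two readings do not differ from each other, so the measured effect of the change on one core is compatible with its effect on the other, and nothing here requires a separate value for each core: the same change on two cores in this assay, a number 8.1 percentage points lower (within the scatter) from compound 1 to compound 3 and a number 14.2 percentage points lower (beyond the scatter) from compound 2 to compound 4, 6.1 percentage points apart, within the scatter of two such steps. This does not show that the change acts more strongly on the core of compound 2 than on the core of compound 1, nor does it establish a fixed size for the step, and two cores say nothing about how the change would behave on a third.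

The compounds shown leave open whether the step belongs to the pyridine nitrogen itself, since only pyridin-2-yl and pyridin-3-yl appear and neither pyridin-4-yl nor a plain phenyl ring stands beside them at that place. Also open, on these data alone, is how the series responds when an amine or a carboxylic acid is carried on the ring, and whether the read-out at this single concentration would hold across a range of concentrations.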